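The source may report more compounds than this note shows. Statements on the series, on what has been measured and on what is new or still open speak of the compounds shown alone.

Measured compounds:
- compound 1, `CCOC(=O)c1oc2ccc(NS(=O)(=O)c3cccc(Cl)c3)cc2c1C`: 53700 nM
- compound 2, `CCOC(=O)c1oc2ccc(NS(=O)(=O)c3ccc(C(F)(F)F)cc3)cc2c1C`: 27200 nM

Of the compounds shown here, two have been tested in a functional assay on MDA-MB-468 cells (Homo sapiens) for antiproliferative activity, read by MTT assay, with a stated time of 72 h; a lower number here means a stronger inhibitor, a higher number a weaker inhibitor. Compound 1 gives 53700 nM there, and compound 2, which carries a trifluoromethyl group instead of chloro, gives 27200 nM. The two numbers lie within the scatter of each other, so no distinction between compound 1 and compound 2 can be drawn from them; both are weak inhibitors in this assay.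

Compound 3, `CCOC(=O)c1oc2ccc(NS(=O)(=O)c3cccc([N+](=O)[O-])c3)cc2c1C`, has not yet been measured. It differs from compound 1 by nitro in place of chloro on an aromatic carbon. For the measured compounds named here, no step between measured compounds describes this exact change. Since compound 1 and compound 2 already show that swapping a substituent on that ring gives no change beyond the scatter, the expectation for the step from compound 1 to compound 3 is a small one, a 1.3-fold lower number from compound 1 to compound 3 (0.11 log units; within the scatter), with no clear direction. The estimate for compound 3 in this assay is therefore 42000 nM, expected to fall between 15000 nM and 120000 nM.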

Compound 3, half-maximal inhibitory concentration: 30100 nM
Compound 3: middle estimate off by 1.4-fold (0.14 log units), on the high side, within the range that was stated.
By their numbers in this assay, from the lowest: compounds 2, 3 and 1 (each within the scatter of the next).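

In this assay, nitro in place of chloro gives a 1.8-fold lower number from compound 1 to compound 3 (0.25 log units; within the scatter), so turning the 3-chlorophenyl group into the 3-nitrophenyl group produces no change that can be told from the scatter. Compound 1 and compound 3 differ in this one place only, which makes this a direct reading for this position on the six-membered aromatic ring, meta to a large group: a single chlorine and a nitro group of 3 heavy atoms and 2 hydrogen-bond acceptors cannot be told apart here. No measurement at hand accounts for this result or connects it to any property of either group.

The compounds shown leave open whether an amine, a methoxy group or a plain hydrogen at this same position would move the number beyond the scatter, since chloro and nitro are only two of the groups that could stand there. They also leave open whether a carboxylic acid in place of the ethyl ester, or any other change to the shared core, would give a stronger inhibitor in this assay.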